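Compound 4: chloro and trifluoromethyl rearranged on the amide

The compounds below may be only part of what the source reports. "The series", "measured", "known", "first", "only" and "open" are said of these compounds alone.

The series keeps one core and varies only the phenyl on the amide carbonyl. Compound 1 `CC(=O)Nc1cccc2c(-c3cccc(NC(=O)c4ccc(Br)c(C)c4)c3)ccnc12` carries bromo and methyl there; in a functional assay on A375P cells (Homo sapiens) for antiproliferative activity, read by MTT assay, with a stated time of 48 h (a higher number here means a weaker inhibitor, a lower number a stronger inhibitor), compound 1 gives only a limit, > 20000 nM. Compound 2 `CC(=O)Nc1cccc2c(-c3cccc(NC(=O)c4ccc(Cl)c(C(F)(F)F)c4)c3)ccnc12` gives 2400 nM in this assay. Compound 3 `CC(=O)Nc1cccc2c(-c3cccc(NC(=O)c4ccc(F)c(C(F)(F)F)c4)c3)ccnc12` gives 6800 nM in this assay. Among the two numbers available, compound 3 stands higher, the step of a 2.8-fold higher number from compound 2 to compound 3 (0.45 log units; beyond the scatter) being modest yet beyond the scatter; against compound 1 only the limit of > 20000 nM in this assay, at which 1 of the 3 values shown sits, is known, so an at least 2.9-fold lower number from compound 1 to compound 3 (0.46 log units; beyond the scatter) and an at least 8.3-fold lower number from compound 1 to compound 2 (0.92 log units; beyond the scatter) are lower bounds.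

Compound 4 `CC(=O)Nc1cccc2c(-c3cccc(NC(=O)c4cc(Cl)cc(C(F)(F)F)c4)c3)ccnc12` differs from compound 3 by 3-chloro-5-(trifluoromethyl)phenyl in place of 4-fluoro-3-(trifluoromethyl)phenyl on a carbonyl carbon. Going by the values given here, no measured step rearranges both substituents on that phenyl; the measured steps only exchange one halogen for another. As far as these compounds go, for compound 4 a small downward step in this assay is expected, a 1.7-fold lower number from compound 3 to compound 4 (0.23 log units; within the scatter), because a 2.8-fold higher number from compound 2 to compound 3 (0.45 log units; beyond the scatter) ran upward when chloro gave way to fluoro, and the rearrangement itself is untested. Compound 4 is expected at 4000 nM, between 1300 nM and 12000 nM.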

Compound 4, half-maximal inhibitory concentration: 6200 nM
Compound 4: the middle estimate sits 1.6-fold (0.19 log units) below what was measured, and the stated range covers the measured number.
By their numbers in this assay, from the lowest: compound 2; then compounds 4 and 3 (each within the scatter of the next). At a limit, above all of these: compound 1.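

In this assay, the new arrangement gives no separation from the fluoro compound: a 1.1-fold lower number from compound 3 to compound 4 (0.04 log units; within the scatter), so compounds 3 and 4 cannot be ordered. With chloro and trifluoromethyl both kept, the arrangement on the phenyl does register, a 2.6-fold higher number from compound 2 to compound 4 (0.41 log units; beyond the scatter), which shows that the 4-chloro-3-(trifluoromethyl)phenyl of compound 2 is not matched simply by carrying the same two groups on that ring. Against compound 1 the step is only a lower bound, an at least 3.2-fold lower number from compound 1 to compound 4 (0.50 log units; beyond the scatter), and the value of compound 1 is a limit: the limit of > 20000 nM in this assay, at which 1 of the 4 values shown sits.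

Open, as far as these compounds go, is whether a nitrile or a methoxy group in place of the chloro of compound 2 would hold its number. Also open, from the compounds shown here alone, is how an amine or a carboxylic acid on this phenyl would read in this assay.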